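Ethyl for methyl on a urea paired with two cores

This account rests on a few compounds, and the source may have more. Where it says the series, first, only, none or still open, it means among the compounds named here.

Measured so far:
Compound 1, `Cc1ccccc1NC(=O)N[C@@H](C)c1ccccc1`: 99%
Compound 2, `Cc1cccc(NC(=O)N[C@H](C)c2ccccc2)c1`: 47%
Compound 3, `CCc1ccccc1NC(=O)N[C@@H](C)c1ccccc1`: 95%

In an ADME assay on the whole organism with Oryza sativa as the target, tested at 10 uM (on this read-out lower numbers stand for a stronger effect and higher numbers for a weaker effect at the one concentration tested), compound 1 gives 99% and compound 3 gives 95%. Compound 3 carries methyl in place of hydrogen on a saturated chain carbon bound to an aromatic carbon, and the step of a number 4 percentage points lower from compound 1 to compound 3 (within the scatter) is small. Compound 2 gives 47%, the strongest effect of the three; the difference between its core and the core of compound 1 is not broken down here. Compound 4, `CCc1cccc(NC(=O)N[C@H](C)c2ccccc2)c1`, has not yet been measured in this assay. It differs from compound 2 by methyl in place of hydrogen on a saturated chain carbon bound to an aromatic carbon, the same change as from compound 1 to compound 3. Because the step of a number 4 percentage points lower from compound 1 to compound 3 (within the scatter) stayed within the scatter, the step of a number 2 percentage points lower from compound 2 to compound 4 (within the scatter) is expected to be small as well. Compound 4 is therefore estimated at 45%, likely between 30% and 65%.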

Compound 4, a percentage reported as activity, at one concentration (the size of the read-out at that concentration, not a potency): 36%
Compound 4: middle estimate off by 9 percentage points, on the high side; measured number inside the range.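

Going from methyl to ethyl in this assay gives a number 11 percentage points lower from compound 2 to compound 4 (beyond the scatter). Set beside the earlier step, the change carries from one core to the other with no difference in size that can be told apart: the same change on two cores in this assay, a number 4 percentage points lower (within the scatter) from compound 1 to compound 3 and a number 11 percentage points lower (beyond the scatter) from compound 2 to compound 4, 7 percentage points apart, within the scatter of two such steps This rests on a single pair on each core, only one of the two steps lies beyond the scatter, and it shows nothing about how the change would behave on any further core.

The compounds shown leave open whether a longer chain such as propyl would continue the step seen with ethyl on either core. They also leave open what an amine or a carboxylic acid at that place would do.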